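The compounds below may be only part of what the source reports. "The series", "measured", "known", "first", "only" and "open" are said of these compounds alone.

Measured in a functional assay on the whole organism (strain Swiss) with Mus musculus as the target, in the maximal electroshock model, with a stated time of 1 h, at a dose of 300 mg/kg by the intraperitoneal route; a lower number here means a weaker effect, a higher number a stronger effect of the compound at the dose given:

compound 1, `CC(C(=O)N1CCN(c2ccccc2C(F)(F)F)CC1)N1C(=O)CCC1=O`: 75%
compound 2, `CC(C(=O)N1CCOCC1)N1C(=O)CCC1=O`: 0%
compound 3, `CCC(C(=O)N1CCN(c2cccc(C(F)(F)F)c2)CC1)N1C(=O)CCC1=O`: 100%

Compound 1 holds the second highest of the three numbers. Compound 3 gives a higher value, a gap beyond the usual scatter, while compound 2 gives a lower value, again beyond the scatter. Together the three span the whole range of the read-out.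

The step considered here leads from compound 1 to compound 4, `CC(C(=O)N1CCN(c2ccccc2)CC1)N1C(=O)CCC1=O`, which has not yet been measured. The change is hydrogen in place of trifluoromethyl on an aromatic carbon, so only a small part of the structure is altered, leaving the shared core and the amide untouched.

Among the measured compounds shown here, no step between measured compounds shows what removing the trifluoromethyl group does. A downward step in this assay is expected, of moderate size and beyond the scatter, because compound 1 already gives 75% with the group in place. The expected step is a number 20 percentage points lower from compound 1 to compound 4 (beyond the scatter). For compound 4 the estimate is 55%, within a range from 20% to 90%.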

Compound 4, a percentage reported as activity, at one dose (the size of the read-out at that dose, not a potency): 50%
Compound 4: middle estimate off by 5 percentage points, on the high side; low and high end bracket the measured number.
By their numbers in this assay, from the lowest: compound 2; then compound 4; then compound 1; then compound 3.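

Replacing trifluoromethyl with hydrogen on this aromatic carbon, ortho to a large group, gives in this assay a number 25 percentage points lower from compound 1 to compound 4 (beyond the scatter), the first direct reading of this change among the compounds shown. The group is not required for an effect at this dose: compound 4, which lacks it, still gives 50% and so keeps a clear part of the effect seen with trifluoromethyl in place. Nothing available explains why the number falls on this change.

As far as these compounds go, whether a chlorine atom, a methoxy group or a nitrile on the same carbon would match trifluoromethyl or hydrogen remains open. Compound 3 differs from compound 1 in more than one place, so it does not show how moving the trifluoromethyl group alone would act.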